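A few compounds are considered here, and "the series" means these few. Any claim that something is new, unique, unknown or untested is made for them only; others in the source may bear on it.

Working notes on the series. Compound 3 `CC1=CCC[C@](C)(CC/C(C)=C/CC2=C(O)C(=O)C=C(N[C@@H](CO)C(=O)O)C2=O)[C@@H]1C` in an ADME assay on KB cells (Homo sapiens) for cytotoxicity, with a stated time of 48 h (a lower number here means a stronger inhibitor, a higher number a weaker inhibitor), gives only a limit, > 10 ug/mL. Compound 1 `CC1=CCC[C@](C)(CC/C(C)=C/CC2=C(O)C(=O)C=C(N[C@@H](C(=O)O)[C@@H](C)O)C2=O)[C@@H]1C` likewise returns only a limit in this assay, > 10 ug/mL. Compound 2 `C=C1[C@H](C)CCC[C@]1(C)CC/C(C)=C/CC1=C(O)C(=O)C=C(N[C@H](C(=O)O)[C@H](C)O)C1=O` also returns only a limit in this assay, > 10 ug/mL. Compound 3 therefore stands with the other two at the limit of > 10 ug/mL in this assay, at which 3 of the 3 values shown sit, and no value in the set is a number. Among the compounds with values here, the one step between measured compounds that differ in one place, a step that the two limits leave unreadable from compound 1 to compound 3, is of unreadable size, the two limits leaving neither direction nor magnitude to be read.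

Compound 4 `CC1=CCC[C@](C)(CC/C(C)=C/CC2=C(O)C(=O)C=C(N[C@H](C(=O)O)[C@H](C)O)C2=O)[C@@H]1C` remains unmeasured; its change from compound 3 is methyl in place of hydrogen on a saturated chain carbon bound to an oxygen on a saturated carbon and a saturated chain carbon. The step that the two limits leave unreadable from compound 1 to compound 3 covers the same exchange in the reverse direction and is the only one bearing on it, but being unreadable it gives no expected size. With all three values sitting at the limit of > 10 ug/mL in this assay, at which 3 of the 3 values shown sit, the expectation for a step that the limit leaves unreadable from compound 3 to compound 4 is no readable step, and compound 4 is expected to return only the limit once more. The estimate for compound 4 in this assay is 15 ug/mL, with a range from 8 ug/mL to 40 ug/mL.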

Compound 4, half-maximal inhibitory concentration: > 10 ug/mL
Compound 4 ended at the assay's limit; the forecaster's own chance of this, stated with the estimate: 85%; the middle value is on the limit's open side.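

Compound 4 returns a limit, as do compounds 1, 2 and 3, so no new step can be read from it to any of them: the limit of > 10 ug/mL in this assay, at which 4 of the 4 values shown sit. The compounds shown leave open whether the methyl-for-hydrogen exchange or the difference in configuration changes the read-out in this assay at all.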